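Replacing the sulfo group on the phenyl ring with hydroxy

The compounds below may be only part of what the source reports. "The series", "measured", "known", "first", "only" and "open" are said of these compounds alone.

Compound 1 `Cc1[nH]n(-c2cccc(C(F)(F)F)c2)c(=O)c1/N=N/c1c(O)cc(S(=O)(=O)O)c2ccccc12`: 62%
Compound 2 `Cc1[nH]n(-c2ccc(S(=O)(=O)O)cc2)c(=O)c1/N=N/c1c(O)cc(S(=O)(=O)O)c2ccccc12`: < 5%

Compound 1 `Cc1[nH]n(-c2cccc(C(F)(F)F)c2)c(=O)c1/N=N/c1c(O)cc(S(=O)(=O)O)c2ccccc12` in an assay on BaF3 cells with thrombopoietin receptor (Homo sapiens) as the target, read by a luciferase reporter (on this read-out lower numbers stand for smaller maximal responses and higher numbers for larger maximal responses), reaches 62%. Compound 2 `Cc1[nH]n(-c2ccc(S(=O)(=O)O)cc2)c(=O)c1/N=N/c1c(O)cc(S(=O)(=O)O)c2ccccc12` carries a 4-sulfophenyl in place of the 3-(trifluoromethyl)phenyl on the aromatic nitrogen, and in this assay compound 2 reports only a limit, < 5% (the limit of < 5% in this assay, at which 1 of the 2 values shown sits). The step of a number at least 57 percentage points lower from compound 1 to compound 2 (beyond the scatter) is therefore a large loss of maximal response.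

Compound 3 `Cc1[nH]n(-c2ccc(O)cc2)c(=O)c1/N=N/c1c(O)cc(S(=O)(=O)O)c2ccccc12` keeps the shared core of compound 2 and differs only at the phenyl ring: hydroxy in place of sulfo on an aromatic carbon. The sulfo group that entered in the harmful step from compound 1 to compound 2 leaves again, yet the 3-(trifluoromethyl)phenyl of compound 1 does not return. Within the data shown here, the only measured step bears on this change indirectly, and no measured pair shows hydroxy against sulfo. A partial recovery toward compound 1 is expected rather than a full one. For compound 3 the estimated step is a number at least 25 percentage points higher from compound 2 to compound 3 (beyond the scatter), and compound 3 is expected to give 30%, within the range 5% to 60% in this assay.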

Compound 3, largest response reached (reported as efficacy), in percent of the reference or control that the assay uses: < 5%
Compound 3 gave a limit, no number; the forecaster's own chance of this, stated with the estimate: 30%; middle value at least 25 percentage points from the limit.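

In this assay the step reads a number at least 57 percentage points lower from compound 1 to compound 3 (beyond the scatter), so a 4-hydroxyphenyl on the aromatic nitrogen, like the 4-sulfophenyl, does not keep the response seen with the 3-(trifluoromethyl)phenyl, and the loss does not require the sulfo group to be present. The entries for compound 2 and compound 3 are both limits of the assay and not numbers, and the step between them cannot be read. Hydroxy and sulfo at this place therefore cannot be ranked against each other, and the two compounds end at the same reading: the limit of < 5% in this assay, at which 2 of the 3 values shown sit.

Still open, on these data alone, is whether the response follows the trifluoromethyl group itself or the place it holds on the phenyl ring, a question that a 4-(trifluoromethyl)phenyl or a 3-hydroxyphenyl on the same nitrogen would address. Also open, as far as these compounds go, is where groups such as chloro, methyl or an amine would fall on the phenyl ring, and whether any group other than trifluoromethyl can give a response that rises clear of the limit in this assay.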